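Toward Compound 4: What the Tolerance Limits Suggest

The source may hold more compounds than are shown below. What is called first, only, known or untested is meant among the compounds shown, and "the series" means these compounds.

Compound 1 `CC(C)CCn1nc(-c2cccs2)c(O)c(C2=NS(=O)(=O)c3cc(NS(=O)(=O)C4CC4)ccc3N2)c1=O`: > 1000 nM
Compound 2 `CC(C)CCn1nc(-c2cccs2)c(O)c(C2=NS(=O)(=O)c3cc(S(C)(=O)=O)ccc3N2)c1=O`: "not determined" (no result reported)
Compound 3 `CC(C)CCn1nc(-c2ccn(C)c2)c(O)c(C2=NS(=O)(=O)c3cc(NS(C)(=O)=O)ccc3N2)c1=O`: > 1000 nM

All three were examined in an ADME assay on Huh-7 cells (Homo sapiens) for cytotoxicity, with a stated time of 72 h; a lower number here means that less compound is tolerated, a higher number that more compound is tolerated. For compound 1 the reported result is a limit of the assay rather than a number, > 1000 nM. For compound 3 the result is likewise a limit, > 1000 nM. Compound 2 shows "not determined" (no result reported) in this assay. So compound 3 stands on a limit only, with one further limit beside it and one entry without a single number; no step between measured compounds can be calculated from these results.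

Compound 4 `C/C(=C\c1nn(CCC(C)C)c(=O)c(C2=NS(=O)(=O)c3cc(NS(C)(=O)=O)ccc3N2)c1O)C(F)(F)F` differs from compound 3 at one place: 2-(trifluoromethyl)prop-1-en-1-yl in place of 1-methyl-1H-pyrrol-3-yl on an aromatic carbon. Among the compounds with values here, because the measured compounds give nothing beyond a limit, there is no measured step to lean on. The expectation is that the change from compound 3 to compound 4 produces no step beyond the scatter, a step that the limit leaves unreadable from compound 3 to compound 4, an expectation that rests on (the limit of > 1000 nM in this assay, at which 2 of the 3 values shown sit). For compound 4 the estimated half-maximal cytotoxic concentration is 1500 nM, with the range 700 nM to 6000 nM, and most likely the assay will again report only a limit.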

Compound 4, half-maximal cytotoxic concentration: > 33000 nM
Compound 4: only a limit was reported; the forecaster's own chance of this, stated with the estimate: 80%; middle value at least 22-fold (1.34 log units) away from the limit.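

In this assay compound 3 is reported only as a limit, > 1000 nM. Compound 4 is also reported only as a limit, > 33000 nM. Within the data shown here, with two limits, no step between compound 3 and compound 4 can be read. The compounds shown leave open the actual half-maximal cytotoxic concentration of each, and whether 2-(trifluoromethyl)prop-1-en-1-yl in place of 1-methyl-1H-pyrrol-3-yl changes tolerance at all.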